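A few compounds are considered here, and "the series" means these few. Any claim that something is new, unique, unknown or untested is made for them only; others in the source may bear on it.

Compound 1, `CC/C(=C(/c1ccc(NC(=O)C(C)C)cc1)c1ccc(OC)cc1)c1ccccc1`, carries a methoxyphenyl group on its core; in a functional assay on MCF7 cells (Homo sapiens) for inhibition, read by trypan blue exclusion, with a stated time of 72 h (on this read-out higher numbers stand for weaker inhibition of growth and lower numbers for stronger inhibition of growth), compound 1 reaches only the limit of > 30000 nM. Compound 2, `CC/C(=C(/c1ccc(NC(=O)C(C)C)cc1)c1ccc(OC)cc1)c1ccc(Cl)cc1Cl`, differs by 2,4-dichlorophenyl in place of phenyl on a double-bonded chain carbon bound to a double-bonded chain carbon and a saturated chain carbon and in this assay compound 2 gives 6600 nM, so that the step is an at least 4.5-fold lower number from compound 1 to compound 2 (0.65 log units; beyond the scatter). Compound 3, `CC/C(=C(/c1ccccc1)c1ccc(NC(=O)C(C)C)cc1)c1ccccc1`, has a core whose difference from that of compound 1 is not broken down here. In this assay compound 3 also stops at the limit of > 30000 nM. Compound 4, `CC/C(=C(/c1ccccc1)c1ccc(NC(=O)C(C)C)cc1)c1ccc(Cl)cc1Cl`, has not yet been measured; it differs from compound 3 by 2,4-dichlorophenyl in place of phenyl on a double-bonded chain carbon bound to a double-bonded chain carbon and a saturated chain carbon, the same change as before. Compound 4 is expected to show a step of an at least 2.5-fold lower number from compound 3 to compound 4 (0.39 log units; beyond the scatter), a size resting on an at least 4.5-fold lower number from compound 1 to compound 2 (0.65 log units; beyond the scatter) and on (the limit of > 30000 nM in this assay, at which 2 of the 3 values shown sit). Compound 4 is therefore estimated at 12000 nM, between 4000 nM and 40000 nM.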

Compound 4, concentration for 50% growth inhibition: 17500 nM
Compound 4: the middle estimate sits 1.5-fold (0.16 log units) below what was measured; measured number inside the range.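

In this assay, 2,4-dichlorophenyl in place of phenyl on the core of compound 3 gives an at least 1.7-fold lower number from compound 3 to compound 4 (0.23 log units; that floor lies within the scatter), so the change can be carried to this second core, but the part of the step that is secured does not clear the scatter on its own. Set beside the earlier step, the result shows no firm difference between the two cores, and it does not give a true size for the change on either: the same change on two cores in this assay, an at least 4.5-fold lower number (0.65 log units; beyond the scatter) from compound 1 to compound 2 and an at least 1.7-fold lower number (0.23 log units; that floor lies within the scatter) from compound 3 to compound 4; the limit leaves it open whether they differ. Compound 1 and compound 3 both start from a limit and not from a number: the limit of > 30000 nM in this assay, at which 2 of the 4 values shown sit.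

The compounds shown leave open how a phenyl bearing a single chlorine, or fluorine in place of chlorine, would read on either core. They also leave open whether an amine on the core would alter the step.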